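A few compounds are considered here, and "the series" means these few. Any claim that something is new, unique, unknown or untested is made for them only; others in the source may bear on it.

Three members of this series are in hand: compound 1 `Cc1c(-c2ccccc2)sc(N)c1C(=O)c1ccc(Cl)cc1`, compound 2 `CC(C)(C)Cc1c(-c2cc(F)ccc2F)sc(N)c1C(=O)c1ccc(Cl)cc1` and compound 3 `CC(C)(C)Cc1c(-c2ccc(Cl)c(Cl)c2)sc(N)c1C(=O)c1ccc(Cl)cc1`. In an assay on CHO cells for displacement of a labelled ligand from adenosine receptor A1 (Homo sapiens), read by scintillation counting, tested at 10 uM (a lower number here means less inhibition, a higher number more inhibition at the concentration tested (going by the name of the read-out)), compound 1 gives 1%, compound 2 gives 3% and compound 3 gives 1%. Compound 3 thus stands level with compound 1 at the digits shown, and the only single-point step measured, a number 2 percentage points lower from compound 2 to compound 3 (within the scatter), exchanges one substituted phenyl for another. The next compound is compound 4 `CC(C)(C)Cc1c(-c2ccccc2)sc(N)c1C(=O)c1ccc(Cl)cc1`, which differs from compound 3 as follows: phenyl in place of 3,4-dichlorophenyl on an aromatic carbon. Compound 1 already carries phenyl on that ring carbon and sits at the same level as compound 3, so no step beyond the scatter is expected in this assay. For compound 4 the expected result is 2%, between -5% and 9%, meaning an estimated step of a number 1 percentage points higher from compound 3 to compound 4 (within the scatter).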

Compound 4, a percentage reported as inhibition, at one concentration (the size of the read-out at that concentration, not a potency): 1%
Estimate against measurement, compound 4: 1 percentage points above; measured number inside the range.
By their numbers in this assay, from the lowest: compounds 1, 3, 4 and 2 (each within the scatter of the next).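

In this assay, phenyl at this position reads the same as 3,4-dichlorophenyl (no change at the digits printed from compound 3 to compound 4 (within the scatter)) and as 2,5-difluorophenyl (a number 2 percentage points lower from compound 2 to compound 4 (within the scatter)), so neither halogenated ring separates from the unsubstituted one. With phenyl held constant, tert-butyl in place of hydrogen on the saturated chain carbon also gives no step beyond the scatter (no change at the digits printed from compound 1 to compound 4 (within the scatter)). No other data bear on these readings. As far as these compounds go, whether an amine or a carboxylic acid on the phenyl ring, or a longer chain in place of neopentyl, would lift the inhibition beyond the scatter remains open.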